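Second methoxy on the core of compound 1

The source may report more compounds than this note shows. Statements on the series, on what has been measured and on what is new or still open speak of the compounds shown alone.

Among the compounds with values here, compound 1 `COc1ccnc(Nc2ccc(Cl)c(OCC=C(C)C)c2)n1` is tested in an ADME assay on MT2 cells (Homo sapiens) for cytotoxicity (a higher number here means that more compound is tolerated, a lower number that less compound is tolerated), where compound 1 gives 9000 nM, the highest of the two numbers measured so far. Within the data shown here, the only other measured compound, compound 2 `CNc1ccnc(Nc2ccc(Cl)c(OCC=C(C)C)c2)n1`, gives 690 nM in this assay; the step between them is a 13-fold lower number from compound 1 to compound 2 (1.12 log units; beyond the scatter). Compound 3 `COc1cc(OC)nc(Nc2ccc(Cl)c(OCC=C(C)C)c2)n1` is the next compound and differs from compound 1 by methoxy in place of hydrogen on an aromatic carbon, the new group sitting next to the ring nitrogen. Among the measured compounds shown here, no measured step shows the effect of a methoxy group entering at this place; the step from compound 1 to compound 2 concerns a different exchange on the same ring and only shows that the number can respond strongly to changes there. With nothing pointing in either direction, the expected step is a 1.5-fold lower number from compound 1 to compound 3 (0.18 log units; within the scatter), none beyond the scatter. Compound 3 is therefore estimated at 6000 nM, with a range from 2500 nM to 15000 nM.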

Compound 3, half-maximal cytotoxic concentration: 28000 nM
Estimate against measurement, compound 3: 4.7-fold (0.67 log units) below; the measured number lies above the stated range.
By their numbers in this assay, from the lowest: compound 2; then compound 1; then compound 3.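

In this assay, methoxy in place of hydrogen on the aromatic carbon next to the ring nitrogen gives a 3.1-fold higher number from compound 1 to compound 3 (0.49 log units; beyond the scatter), so this position is not silent and a substituent there can raise the number. Alongside a 13-fold lower number from compound 1 to compound 2 (1.12 log units; beyond the scatter), the core of compound 1 now shows movement in both directions, with the methylamino exchange lowering the number and the added methoxy raising it. No measurement available here speaks to the reason for the rise.

On these data alone, whether the rise is particular to methoxy at this place remains open, since a group such as ethoxy, an amine or a chlorine atom could behave differently. Also open, as far as these compounds go, is whether the added methoxy would raise the number in the same way on the core of compound 2.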